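The source may report more compounds than this note shows. Statements on the series, on what has been measured and on what is new or still open speak of the compounds shown alone.

The study measured three compounds in an ADME assay on BHK cells (Mesocricetus auratus) for cytotoxicity, read by MTT assay, with a stated time of 96 h; a higher number here means that more compound is tolerated, a lower number that less compound is tolerated. Compound 1, `Cn1c(-c2ccc(NC(=O)CN3CCCCC3)cc2)nc2cc(C(F)(F)F)ccc21`, reached the assay limit: in this assay compound 1 gives > 100000 nM, a limit rather than a number. Compound 2, `Cn1c(-c2ccc([N+](=O)[O-])cc2)nc2cc(C(F)(F)F)ccc21`, gives > 100000 nM in this assay, again a limit and not a number. Compound 3, `O=[N+]([O-])c1ccc(-c2nc3cc(C(F)(F)F)ccc3n2C2CCCCC2)cc1`, gives > 100000 nM in this assay, also a limit. Because the three values sit at the limit of > 100000 nM in this assay, at which 3 of the 3 values shown sit, the two steps between them cannot be sized: a step that the two limits leave unreadable from compound 1 to compound 2, and a step that the two limits leave unreadable from compound 2 to compound 3. Compound 3 therefore stands where the other two stand, at the limit, with no number of its own to compare against.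

The next compound, compound 4, `Nc1ccc(-c2nc3cc(C(F)(F)F)ccc3n2C2CCCCC2)cc1`, differs from compound 3 in one place: amino in place of nitro on an aromatic carbon. Neither measured step bears directly on this change: both run between limits, and neither exchanges nitro for amino. Among the measured compounds shown here, the only guide is that every compound so far, compound 3 among them, rested at the limit of > 100000 nM in this assay, at which 3 of the 3 values shown sit, without a readable value. One therefore expects no step beyond the scatter, a number no higher from compound 3 to compound 4 (the limit leaves the size open), from compound 3 to compound 4. Compound 4 is expected to give 100000 nM in this assay, within a range from 50000 nM to 200000 nM, most probably reported once more as a limit.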

Compound 4, half-maximal cytotoxic concentration: > 100000 nM
Compound 4 was reported as a limit; the forecaster's own chance of this, stated with the estimate: 80%; the middle value lies on the limit itself.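

In this assay compound 4 gives > 100000 nM, a limit and not a number. No size can be read for the change from compound 3 to compound 4, because both rest at the same limit: the limit of > 100000 nM in this assay, at which 4 of the 4 values shown sit.

The compounds shown leave open where the half-maximal cytotoxic concentration of any of the four lies, and whether amino in place of nitro shifts it at all.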